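Swapping the Heteroaryl Arm of a Sulfonamide Growth Inhibitor

A few compounds are considered here, and "the series" means these few. Any claim that something is new, unique, unknown or untested is made for them only; others in the source may bear on it.

Compound 1, `COc1cc(CSc2cc(Cl)c(-c3nnc(-c4ccc(Cl)cc4)s3)cc2S(=O)(=O)NC(=N)NO)cc(OC)c1OC`, is the weaker of the two compounds measured in a functional assay on OVCAR-3 cells (Homo sapiens); on this read-out higher numbers stand for weaker inhibition of growth and lower numbers for stronger inhibition of growth: compound 1 gives 10200 nM, the highest of the two numbers. Among the compounds with values here, the only other measured compound, compound 2 (`N=C(NO)NS(=O)(=O)c1cc(-c2nnc(-c3ccc(Cl)cc3)s2)c(Cl)cc1SCc1ccccc1`), gives 1670 nM. Within the data shown here, the single known step, a 6.1-fold lower number from compound 1 to compound 2 (0.79 log units; beyond the scatter), concerns a change at a different place in the molecule. Compound 3, `COc1cc(CSc2cc(Cl)c(-c3nc(-c4ccccc4)no3)cc2S(=O)(=O)NC(=N)NO)cc(OC)c1OC`, differs from compound 1 elsewhere: 3-phenyl-1,2,4-oxadiazol-5-yl in place of 5-(4-chlorophenyl)-1,3,4-thiadiazol-2-yl on an aromatic carbon. Among the measured compounds shown here, no measured pair shows what this exchange does; the step from compound 1 to compound 2 touched only the group on the saturated chain carbon bound to a sulfur and says nothing about the five-membered ring on the aromatic carbon. Without a guide, the expected change in this assay is none beyond the scatter, though the uncertainty around that expectation is wide. The estimate for compound 3 is 12000 nM, with a range from 3000 nM to 45000 nM, which means an expected step of a 1.2-fold higher number from compound 1 to compound 3 (0.07 log units; within the scatter).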

Compound 3, concentration for 50% growth inhibition: 4790 nM
The estimate for compound 3 lay 2.5-fold (0.40 log units) above the measured number; low and high end bracket the measured number.
By their numbers in this assay, from the lowest: compound 2; then compound 3; then compound 1.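

In this assay, within the data shown here, the new step is the first reading at this aromatic carbon, para to a large group: 3-phenyl-1,2,4-oxadiazol-5-yl in place of 5-(4-chlorophenyl)-1,3,4-thiadiazol-2-yl gives a 2.1-fold lower number from compound 1 to compound 3 (0.33 log units; beyond the scatter), so growth inhibition is stronger and the group here does affect the read-out. Both groups consist of a five-membered aromatic ring with three hetero atoms and a six-membered aromatic ring of carbon only, yet the exchange alters several things at once: the chlorine on the outer ring goes, oxygen replaces sulfur in the five-membered ring, and the ring atoms are arranged differently. No measurement shown here gives a reason for the step.

The compounds shown leave open which of these alterations matters, a question that 5-phenyl-1,3,4-thiadiazol-2-yl or 3-(4-chlorophenyl)-1,2,4-oxadiazol-5-yl on the core of compound 1 could help to separate. Also open, from the compounds shown here alone, are whether the same exchange has a similar effect when phenyl replaces 3,4,5-trimethoxyphenyl on the saturated chain carbon bound to a sulfur, and how a simple amine or carboxylic acid would fare at this aromatic carbon.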